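Amide substituent change in the shared core series

This account rests on a few compounds, and the source may have more. Where it says the series, first, only, none or still open, it means among the compounds named here.

Compound 1 `N#Cc1ccc(Cn2cncc2CNc2ccc(C(=O)Nc3cccc([N+](=O)[O-])c3)c(-c3ccccc3)c2)cc1` carries 3-nitrophenyl on the amide-type nitrogen of the shared core. In a functional assay on NIH3T3 cells (Mus musculus) (on this read-out lower numbers stand for an effect already at smaller amounts and higher numbers for an effect only at larger amounts of compound), compound 1 gives only a limit, > 10 uM. Compound 2 `COC(=O)[C@H](CCSC)NC(=O)c1ccc(NCc2cncn2Cc2ccc(C#N)cc2)cc1-c1ccccc1` differs at that same nitrogen. In this assay compound 2 likewise gives only a limit, > 10 uM. The step that the two limits leave unreadable from compound 1 to compound 2 is thus not readable; both values sit at the limit of > 10 uM in this assay, at which 2 of the 2 values shown sit. Compound 3 `N#CCNC(=O)c1ccc(NCc2cncn2Cc2ccc(C#N)cc2)cc1-c1ccccc1` is the next variation: cyanomethyl in place of 1-(methoxycarbonyl)-3-(methylsulfanyl)propyl on an amide-type nitrogen. Among the measured compounds shown here, no measured step bears on this change, and the only comparison available is a pair of limits, so nothing points to a gain or a loss. The step from compound 2 to compound 3 is therefore expected as a step that the limit leaves unreadable from compound 2 to compound 3, with no direction the numbers support. Compound 3 is estimated at 20 uM, with a range from 5 uM to 80 uM, and a reading that is again only a limit is the more likely outcome.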

Compound 3, concentration for half-maximal effect: > 10 uM
Compound 3 gave a limit, no number; the forecaster's own chance of this, stated with the estimate: 75%; the middle value is on the limit's open side.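

Among the compounds shown here, compound 3 gives only a limit in this assay, > 10 uM, so no step among compound 1, compound 2 and compound 3 can be read. The compounds shown leave open how these three amide substituents rank, with every value at one limit: the limit of > 10 uM in this assay, at which 3 of the 3 values shown sit.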